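A few compounds are considered here, and "the series" means these few. Any claim that something is new, unique, unknown or untested is made for them only; others in the source may bear on it.

Compound 1 `O=C(Nc1ccc(NCC2CCCC2)cc1Cl)c1cc(Cl)ccc1O`, compound 2 `O=C(Nc1ccc(NCc2ccc(F)cc2)cc1Cl)c1cc(Cl)ccc1O`, compound 3 `O=C(Nc1ccc(NC2CCCC2)cc1Cl)c1cc(Cl)ccc1O` and compound 4 `O=C(Nc1ccc(NCc2ccccc2)cc1Cl)c1cc(Cl)ccc1O` share one core and differ in the group carried on a nitrogen on an aromatic ring. In an ADME assay on A549 cells (Homo sapiens) for cytotoxicity, read by LDH release, with a stated time of 15 h (a lower number here means that less compound is tolerated, a higher number that more compound is tolerated), compound 1 gives 141000 nM. The entry for compound 2 in this assay reads "not determined" (no result reported). Among the measured compounds shown here, the entry for compound 3 reads "not determined" (no result reported), so compound 3 has no single number, and compound 2 is the only other compound in that position. Compound 4 differs from compound 3 by one structural change: benzyl in place of cyclopentyl on a nitrogen on an aromatic ring. For the measured compounds named here, no step between measured compounds is available to size this change. In this assay, going by the values given here, the change is therefore expected to bring no step beyond the scatter, in either direction, and the only anchor is compound 1 at 141000 nM. For compound 4 the expected value is 100000 nM, with an estimated range from 25000 nM to 250000 nM.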

Compound 4, half-maximal cytotoxic concentration: 81300 nM
Estimate against measurement, compound 4: 1.2-fold (0.09 log units) above; the measured number falls inside the stated range.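

In this assay, among the compounds shown here, the first step at this position can now be read, and it is small: the exchange of cyclopentyl for phenyl on a saturated chain carbon bound to a nitrogen on an aromatic ring gives a 1.7-fold lower number from compound 1 to compound 4 (0.24 log units; within the scatter), so the two compounds cannot be told apart here. The direct step from compound 3 to compound 4 and any step involving compound 2 cannot be read, as neither compound 2 nor compound 3 has a single number, so the shown data size only the exchange of the ring at the end of the chain. No accompanying measurement bears on this result.

From the compounds shown here alone, whether this tolerance holds for a longer chain on the nitrogen remains open. So does the outcome with an amine or a carboxylic acid on the benzyl ring.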